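This account rests on a few compounds, and the source may have more. Where it says the series, first, only, none or still open, it means among the compounds named here.

Measured compounds: compound 1 `COC1=C(C)C(=O)/C(=C(O)/C=C/c2ccc(OC)cc2)C(=O)C1(C)C`, 9.2 ug/mL; compound 2 `COC1=C(C)C(=O)/C(=C(O)/C=C/c2cccc(OC)c2)C(=O)C1(C)C`, 4.5 ug/mL; compound 3 `COC1=C(C)C(=O)/C(=C(O)/C=C/c2ccco2)C(=O)C1(C)C`, 14.7 ug/mL.

In a functional assay on A-431 cells (Homo sapiens) for cytotoxicity (on this read-out higher numbers stand for an effect only at larger amounts of compound and lower numbers for an effect already at smaller amounts), compound 1 stands second highest of the three numbers. Compound 2 lies a 2.0-fold lower number from compound 1 to compound 2 (0.31 log units; beyond the scatter) away, and compound 3 lies a 1.6-fold higher number from compound 1 to compound 3 (0.20 log units; within the scatter) away. Compound 4 `COC1=C(C)C(=O)/C(=C(O)/C=C/c2cccs2)C(=O)C1(C)C` differs from compound 1 by thiophen-2-yl in place of 4-methoxyphenyl on a double-bonded chain carbon bound to a double-bonded chain carbon. Among the measured compounds shown here, the one step that bears on this change is the one to compound 3, where another five-membered aromatic ring with one hetero atom entered in the same place and gave a 1.6-fold higher number from compound 1 to compound 3 (0.20 log units; within the scatter), a shift within the scatter. The account therefore expects no step beyond the scatter, with a slight lean toward a higher number, so that a 1.2-fold higher number from compound 1 to compound 4 (0.08 log units; within the scatter) is estimated. For compound 4 the estimate is 11 ug/mL, with a range from 5 ug/mL to 25 ug/mL.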

Compound 4, concentration for half-maximal effect: 10.8 ug/mL
Estimate against measurement, compound 4: 1.0-fold (0.01 log units) above; the range from low to high includes it.
By their numbers in this assay, from the lowest: compound 2; then compounds 1, 4 and 3 (each within the scatter of the next).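

In this assay thiophen-2-yl, like furan-2-yl, is a five-membered aromatic ring with one hetero atom that stays within the scatter of 4-methoxyphenyl (a 1.2-fold higher number from compound 1 to compound 4 (0.07 log units; within the scatter)), and the two five-membered rings also stay within the scatter of each other (a 1.4-fold lower number from compound 3 to compound 4 (0.13 log units; within the scatter)). Only the step from 3-methoxyphenyl lies beyond the scatter (a 2.4-fold higher number from compound 2 to compound 4 (0.38 log units; beyond the scatter)), so compound 2 alone stands apart among these groups on the double-bonded chain carbon. Nothing at hand explains these steps.

Open, on these data alone, is how an amine or a carboxylic acid on the aromatic ring would read at this place. As far as these compounds go, a longer chain in place of the ring is equally open.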